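The source may report more compounds than this note shows. Statements on the series, on what has been measured and on what is new or still open speak of the compounds shown alone.

In a functional assay on RS4-11 cells (Homo sapiens) for inhibition, read by CCK-8 assay, with a stated time of 48 h, tested at 20 uM (on this read-out higher numbers stand for more inhibition of growth at the one concentration tested and lower numbers for less inhibition of growth), two compounds that share one core and differ on a sulfonyl sulfur have been measured. There, compound 1 `COc1ccc(S(=O)(=O)Oc2ccccc2/C=C(\C#N)C(=O)Nc2nnc(Cc3cccc4ccccc34)s2)cc1` gives 78%, and compound 2 `N#C/C(=C\c1ccccc1OS(=O)(=O)c1ccccc1[N+](=O)[O-])C(=O)Nc1nnc(Cc2cccc3ccccc23)s1` gives 66%, which makes compound 2 the lower of the two. Going by the values given here, the only measured step, a number 12 percentage points lower from compound 1 to compound 2 (beyond the scatter), is modest but lies beyond the scatter. Compound 3 `N#C/C(=C\c1ccccc1OS(=O)(=O)c1ccc(F)cc1)C(=O)Nc1nnc(Cc2cccc3ccccc23)s1` keeps the core of compound 2 and changes the same place: 4-fluorophenyl in place of 2-nitrophenyl on a sulfonyl sulfur. Thus 4-fluorophenyl stands in place of 2-nitrophenyl on a sulfonyl sulfur. Among the compounds with values here, neither measured compound carries 4-fluorophenyl, so the data offer no direct precedent for it. Within the data shown here, the single step of a number 12 percentage points lower from compound 1 to compound 2 (beyond the scatter) is the only guide, showing that a swap at this place can shift the number by a modest amount. Compound 3 gives up the 2-nitrophenyl group of the lower compound, so a small rise is expected, one that may stay within the scatter. The estimated change is a number 7 percentage points higher from compound 2 to compound 3 (within the scatter). For compound 3 the expected value is 73%, with an estimated range from 60% to 86%.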

Compound 3, percent growth inhibition at one concentration: 68%
Compound 3: middle estimate off by 5 percentage points, on the high side, within the range that was stated.
By their numbers in this assay, from the lowest: compounds 2, 3 and 1 (each within the scatter of the next, the first and the last beyond it).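

In this assay, replacing 2-nitrophenyl with 4-fluorophenyl on the sulfonyl sulfur gives a number 2 percentage points higher from compound 2 to compound 3 (within the scatter), so this second swap at the position, unlike the first, produces no difference that can be told from the scatter. Fluoro in place of methoxy on an aromatic carbon gives a number 10 percentage points lower from compound 1 to compound 3 (within the scatter), which places compound 3 within the scatter of both earlier compounds and shows that the three form an unbroken run rather than two separate levels, although the ends of that run remain apart. Nothing available accounts for these numbers, whether through the groups themselves or through the way they act on the cells.

The compounds shown leave open whether the sulfonyl sulfur can carry something other than a substituted phenyl ring, such as a simple methyl group, or whether a phenyl ring bearing an amine or a carboxylic acid would move the number beyond the scatter. They also leave open whether the small differences seen at one concentration would persist across a range of concentrations.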